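A few compounds are considered here, and "the series" means these few. Any claim that something is new, unique, unknown or untested is made for them only; others in the source may bear on it.

In a functional assay on A549 cells (Homo sapiens) for antiproliferative activity, read by MTT assay, with a stated time of 48 h (a lower number here means a stronger inhibitor of growth, a higher number a weaker inhibitor of growth), compound 1 (`CCOc1cc(NC(=O)CCCCCC(=O)Nc2cc(-c3ccccc3)ccc2N)cc2c1OCC([N+](=O)[O-])=C2`) gives 4860 nM, the lowest of the three numbers at hand. Compound 2 (`CCOc1cc(NC(=O)CCCCCCC(=O)Nc2ccccc2N)cc2c1OCC([N+](=O)[O-])=C2`) gives 11700 nM and compound 3 (`CCOc1cc(NC(=O)CCCCC(=O)Nc2cc(-c3ccc(C)s3)ccc2N)cc2c1OCC([N+](=O)[O-])=C2`) gives 13800 nM, both higher by more than the scatter. Compound 4 (`CCOc1cc(NC(=O)CCCCCC(=O)Nc2cc(-c3ccc(C)s3)ccc2N)cc2c1OCC([N+](=O)[O-])=C2`) departs from compound 1 in one place: 5-methylthiophen-2-yl in place of phenyl on an aromatic carbon, para to an amino group (5-methylthiophen-2-yl in place of phenyl on an aromatic carbon). Among the measured compounds shown here, no measured pair isolates this change. Compound 3 also carries the 5-methylthiophen-2-yl group and stands at 13800 nM, so a modest rise in this assay is expected, possibly within the scatter. The expected change is a 1.4-fold higher number from compound 1 to compound 4 (0.16 log units; within the scatter). For compound 4 the estimated value is 7000 nM, with an expected range of 3000 nM to 16000 nM.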

Compound 4, concentration for 50% growth inhibition: 5070 nM
For compound 4 the middle estimate is 1.4-fold (0.14 log units) above the measured one; the range from low to high includes it.
By their numbers in this assay, from the lowest: compounds 1 and 4 (each within the scatter of the next); then compounds 2 and 3 (each within the scatter of the next).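

In this assay, among the compounds shown here, the exchange of phenyl for 5-methylthiophen-2-yl, on the aromatic carbon para to an amino group, gives a 1.0-fold higher number from compound 1 to compound 4 (0.02 log units; within the scatter) and so isolates this change for the first time. At this position, on this chain, a five-membered aromatic ring with one hetero atom stands level with the six-membered carbon ring. Nothing at hand gives a reason for this. The compounds shown leave open whether an amine or a carboxylic acid on this aromatic carbon would shift the number in this assay and whether the exchange holds on a longer chain.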